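Swapping the ether group toward the amide-bearing pyridine

This account rests on a few compounds, and the source may have more. Where it says the series, first, only, none or still open, it means among the compounds named here.

Two compounds share a core built from an amine-linked pyrimidine and an aryl ether, and differ in both outer groups. Compound 1 `CNC(=O)c1cc(Oc2ccc(Nc3nccc(N4CCCCC4)n3)cc2)ccn1` carries a piperidine on the pyrimidine and a methylcarbamoyl pyridyl ether; in a functional assay on HCT-116 cells (Homo sapiens) for inhibition, read by MTT assay, with a stated time of 72 h, tested at 20 uM (on this read-out lower numbers stand for less inhibition and higher numbers for more inhibition at the one concentration tested (going by the name of the read-out)), compound 1 gives 69.8%. Compound 2 `c1ccc2c(c1)CCN(c1ccnc(Nc3ccc(Oc4ncnc5sccc45)cc3)n1)C2` carries a tetrahydroisoquinoline and a thienopyrimidine ether; in this assay compound 2 gives 18.1%, the lower of the two numbers, and its distance from compound 1 lies beyond the usual scatter.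

Compound 3 `CNC(=O)c1cc(Oc2ccc(Nc3nccc(N4CCc5ccccc5C4)n3)cc2)ccn1` keeps the tetrahydroisoquinoline of compound 2 and takes over the ether group of compound 1. The change is a group of 10 heavy atoms (7 carbon, 2 nitrogen, 1 oxygen; one six-membered aromatic ring with 1 hetero atom) in place of a group of 9 heavy atoms (6 carbon, 2 nitrogen, 1 sulfur; one five-membered aromatic ring with 1 hetero atom, one six-membered aromatic ring with 2 hetero atoms), on an oxygen on an aromatic ring.

Among the measured compounds shown here, no measured pair isolates this swap. For the measured compounds named here, still, the ether group now entering is the one present in compound 1, whose value 69.8% stands far above that of compound 2, so an increase in this assay is expected, estimated as a number 36.9 percentage points higher from compound 2 to compound 3 (beyond the scatter). Compound 3 is therefore expected to give about 55%, within a range from 30% to 78%.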

Compound 3, a percentage reported as inhibition, at one concentration (the size of the read-out at that concentration, not a potency): 31.2%
Beside the measured number, compound 3's estimate is 23.8 percentage points above it; the measured number falls inside the stated range.
By their numbers in this assay, from the lowest: compound 2; then compound 3; then compound 1.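

With the 1,2,3,4-tetrahydroisoquinolin-2-yl group held constant, the ether position can now be read on its own in this assay: 2-(methylcarbamoyl)pyridin-4-yl on the oxygen gives a number 13.1 percentage points higher from compound 2 to compound 3 (beyond the scatter), a modest step. The other outer position, which the first two compounds could not separate from the ether change, carries the larger step, since 1,2,3,4-tetrahydroisoquinolin-2-yl in place of piperidin-1-yl on the aromatic carbon gives a number 38.6 percentage points lower from compound 1 to compound 3 (beyond the scatter). Nothing measured here explains either step.

Among the compounds shown here, each change has been read against only one partner group, so whether the ether step holds with piperidin-1-yl in place remains open. On these data alone, how a morpholine or a dimethylamino group on that aromatic carbon would compare with these two groups also remains open.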